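The source may hold more compounds than are shown below. What is called first, only, known or untested is meant among the compounds shown, and "the series" means these compounds.

In a functional assay on NCI-H460 cells (Homo sapiens) for antiproliferative activity, read by MTT assay, with a stated time of 24 h (on this read-out higher numbers stand for weaker inhibition and lower numbers for stronger inhibition), three compounds on the shared core have been read so far. Compound 1 `Cc1cc(=O)n2nc(SCc3ccc(F)cc3)nc2[nH]1` gives > 80000 nM, which is a limit of the assay and not a number. Compound 2 `Cc1cc(=O)n2nc(SCc3ccc(C(C)C)cc3)nc2[nH]1` gives 31800 nM, and compound 3 `Cc1cc(=O)n2nc(SCc3cccc(C(F)(F)F)c3)nc2[nH]1` gives 65800 nM. Compound 2 therefore holds the lowest of the actual numbers, and compound 3 is its nearest neighbour, with a gap just beyond the scatter.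

Compound 4 `Cc1cc(=O)n2nc(SCc3ccc([N+](=O)[O-])cc3)nc2[nH]1`, not yet measured, has nitro in place of isopropyl on an aromatic carbon, para to a large group: nitro in place of isopropyl on an aromatic carbon. Within the data shown here, the one measured step at this place is an at least 2.5-fold lower number from compound 1 to compound 2 (0.40 log units; beyond the scatter), with isopropyl in place of fluoro. The size of that step is only a minimum, as it rests on (the limit of > 80000 nM in this assay, at which 1 of the 3 values shown sits). Among the measured compounds shown here, no measured compound carries nitro, so this step gives a direction more than a size: removing isopropyl is expected to lose some or all of that gain in this assay. The expected change is a 2.0-fold higher number from compound 2 to compound 4 (0.31 log units; beyond the scatter), a modest step to a higher number that only narrowly clears the scatter. A reading at the assay limit would not be surprising. For compound 4 the estimated value is 65000 nM, with an expected range of 30000 nM to 140000 nM.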

Compound 4, half-maximal inhibitory concentration: > 80000 nM
Compound 4: a limit, no number; the forecaster's own chance of this, stated with the estimate: 35%; middle value at least 1.2-fold (0.09 log units) away from the limit.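

In this assay, nitro in place of isopropyl on the aromatic carbon para to a large group gives an at least 2.5-fold higher number from compound 2 to compound 4 (0.40 log units; beyond the scatter), so a second replacement of isopropyl at this place also moves to a higher number, and this size is only a minimum. Of compound 1, compound 2 and compound 4, which differ only at this place, compound 2 alone gives a reading that is an actual number, 31800 nM, and no compound among these three goes against that; the observation reaches no further than these three. The step from compound 1 to compound 4 cannot be read, and fluoro and nitro cannot be ordered against each other, because both compounds rest on the same limit: the limit of > 80000 nM in this assay, at which 2 of the 4 values shown sit.

On these data alone, what stays open is whether the lower number belongs to isopropyl alone or would also come with another carbon group at this place, such as methyl, tert-butyl or a longer chain. As far as these compounds go, it is equally open how an amine or a carboxylic acid on this aromatic carbon would read in this assay, and whether any group here could reach a number well below that of compound 2.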